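From 3-methylphenyl to 2-fluoropyridin-3-yl on the sulfonyl sulfur

The source may hold more compounds than are shown below. What is called first, only, known or untested is meant among the compounds shown, and "the series" means these compounds.

In an ADME assay on HCT-116 cells (Homo sapiens) for cytotoxicity, read by CellTiter-Glo, with a stated time of 72 h (a higher number here means a weaker inhibitor, a lower number a stronger inhibitor), compound 3 (`Cc1cccc(S(=O)(=O)N2CCC(N3CCC(C)CC3)CC2)c1`) gives > 5000 nM, which is a limit and not a number. Compound 1 (`CC1CCN(C2CCN(S(=O)(=O)c3cccnc3)CC2)CC1`) gives > 10000 nM, also a limit. Compound 2 (`CC1CCN(C2CCN(S(=O)(=O)c3cnc(Cl)s3)CC2)CC1`) gives > 10000 nM, again a limit. No exact value is available for any of the three.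

Compound 4 (`CC1CCN(C2CCN(S(=O)(=O)c3cccnc3F)CC2)CC1`) carries a new group on the sulfonyl sulfur: 2-fluoropyridin-3-yl in place of 3-methylphenyl on a sulfonyl sulfur. The measured changes at this same place are a step that the two limits leave unreadable from compound 1 to compound 3, a step that the two limits leave unreadable from compound 2 to compound 3 and a step that the two limits leave unreadable from compound 1 to compound 2. None of them has a size that can be carried over, and none gives a direction. No step beyond the scatter is therefore expected in this assay. The expected change is a step that the limit leaves unreadable from compound 3 to compound 4. A further limit is the most likely report, an expectation that rests on (the limit of > 10000 nM in this assay, at which 2 of the 3 values shown sit). Compound 4 is estimated at 10000 nM, with an expected range from 4000 nM to 25000 nM.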

Compound 4, half-maximal inhibitory concentration: > 10000 nM
Compound 4 was reported as a limit; the forecaster's own chance of this, stated with the estimate: 85%; the middle value lies on the limit itself.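

Compound 4 is reported only as a limit in this assay, as are compound 1, compound 2 and compound 3, so none of the steps among these four compounds can be read. The compounds shown leave open whether any group on the sulfonyl sulfur changes cytotoxicity, and in which direction.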